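This account rests on a few compounds, and the source may have more. Where it says the series, first, only, none or still open, it means among the compounds named here.

Compound 1, `O=C(NCCCCn1cccn1)c1cccc(C2SCC(=O)N2c2cccnc2)c1`, gives in a functional assay on HOS-TE85 cells (Homo sapiens) for inhibition, read by CCK-8 assay, with a stated time of 72 h (on this read-out lower numbers stand for stronger inhibition and higher numbers for weaker inhibition), only a limit, > 1000 nM.
Compound 2, `COc1cccc(OC)c1N1C(=O)CSC1c1cccc(C(=O)NCCCCc2ccccc2)c1`, gives in this assay only a limit, > 1000 nM.
Compound 3, `Cc1ccnc(N2C(=O)CS[C@H]2c2cccc(C(=O)NCCCCn3cccn3)c2)c1`, gives in this assay only a limit, > 10000 nM.

None of the three measured compounds yields a number in this assay. Compound 2 stands at a limit, and the two further values shown are limits as well; two of the three sit at the limit of > 1000 nM in this assay, at which 2 of the 3 values shown sit, while the third sits at the limit of > 10000 nM in this assay, at which 1 of the 3 values shown sits. Among the measured compounds shown here, with no numbers among them, no step between measured compounds can be sized, and no pattern among the three can be drawn beyond the fact that all remain at or past the limits of this assay.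

Compound 4, `O=C(NCCCCc1ccccc1)c1cccc(C2SCC(=O)N2c2ccccc2F)c1`, differs from compound 2 in one place: 2-fluorophenyl in place of 2,6-dimethoxyphenyl on an amide-type nitrogen in a ring. The rest of the shared core and the four-carbon chain ending in a phenyl ring on the amide side are kept.

Since compound 2 offers only a limit, no direction can be read for this change, and the step from compound 2 to compound 4 is expected to be a step that the limit leaves unreadable from compound 2 to compound 4, that is, none beyond the scatter. Compound 4 is therefore estimated at 3000 nM, within a range from 800 nM to 30000 nM, most likely reported again only as a limit.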

Compound 4, half-maximal inhibitory concentration: 34.1 nM
Beside the measured number, compound 4's estimate is 88-fold (1.94 log units) above it; measured number outside the range, below it.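

In this assay, compound 4 is the first of the compounds shown to give a number rather than a limit, and it shows that the group on the amide-type nitrogen in the ring can decide the outcome. Among the compounds shown here, with the shared core and the four-carbon chain ending in a phenyl ring kept, putting 2-fluorophenyl in place of 2,6-dimethoxyphenyl gives an at least 29-fold lower number from compound 2 to compound 4 (1.46 log units; beyond the scatter), a large step that the earlier compounds, all limits, could not reveal. This size is only a lower bound, because compound 2 stands at a limit and not at a number: the limit of > 1000 nM in this assay, at which 2 of the 4 values shown sit.

The compounds shown do not separate the entry of the fluorine from the loss of the two methoxy groups, so a plain phenyl, a 2-methoxyphenyl or a 2-chlorophenyl group at this position would be needed to tell which part of the change matters. On these data alone, it also remains open whether 2-fluorophenyl has a similar effect when the chain ends in a pyrazole ring rather than a phenyl ring, and why this change acts as it does cannot be read from these values.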